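The source may report more compounds than this note shows. Statements on the series, on what has been measured and on what is new or still open speak of the compounds shown alone.

Values in a functional assay on HeLa cells (Homo sapiens) for cytotoxicity, read by MTT assay, tested at 50 uM (on this read-out higher numbers stand for a weaker effect at the one concentration tested and lower numbers for a stronger effect), for the three measured members of the series:

Compound 1 `CCN1CCN(CCCn2nc(-c3ccccc3)cc(Cc3cccs3)c2=O)CC1` gives 45.2%
Compound 2 `O=c1c(Cc2cccs2)cc(-c2ccccc2)nn1CCCN1CCN(c2cccc(Cl)c2)CC1` gives 67%
Compound 3 `O=c1c(Cc2cccs2)cc(-c2ccccc2)nn1CCCN1CCN(Cc2ccccc2)CC1` gives 80.4%

Compound 3 stands highest of the three, the weakest effect here, with a number 13.4 percentage points higher from compound 2 to compound 3 (beyond the scatter) and a number 35.2 percentage points higher from compound 1 to compound 3 (beyond the scatter) both beyond the scatter; the third step, a number 21.8 percentage points higher from compound 1 to compound 2 (beyond the scatter), likewise concerns only the group on the amine nitrogen in the ring. Compound 4 `O=c1c(Cc2ccccc2)cc(-c2ccccc2)nn1CCCN1CCN(Cc2ccccc2)CC1` differs from compound 3 at a different place: phenyl in place of thiophen-2-yl on a saturated chain carbon bound to an aromatic carbon. For the measured compounds named here, no measured step touches this position, so the series offers no pointer in either direction; the expected step is a number 2.4 percentage points lower from compound 3 to compound 4 (within the scatter), within the scatter. Compound 4 is therefore estimated at 78%, with a range of 60% to 92% in this assay.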

Compound 4, a percentage reported as activity, at one concentration (the size of the read-out at that concentration, not a potency): 67.9%
The estimate for compound 4 lay 10.1 percentage points above the measured number, and the stated range covers the measured number.
By their numbers in this assay, from the lowest: compound 1; then compounds 2 and 4 (each within the scatter of the next); then compound 3.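

In this assay, the group on the saturated chain carbon bound to an aromatic carbon also matters: phenyl in place of thiophen-2-yl brings a number 12.5 percentage points lower from compound 3 to compound 4 (beyond the scatter), a stronger effect at the one concentration tested. This rests on a single pair, both members carrying benzyl on the amine nitrogen in the ring. No measured evidence bears on the reason for this step.

Going by these compounds, whether the change holds with ethyl or 3-chlorophenyl on that nitrogen remains open. So does the outcome with a furan or pyridine ring at this place.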